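Aryl sulfonate ureas: hydroxyphenyl swap on a second core

The compounds below may be only part of what the source reports. "The series", "measured", "known", "first", "only" and "open" are said of these compounds alone.

Compound 1 `CCNC(=O)Nc1cccc(S(=O)(=O)Oc2ccccc2CC)c1`: 33000 nM
Compound 2 `CCNC(=O)Nc1cccc(S(=O)(=O)Oc2ccc(O)cc2)c1`: 75000 nM
Compound 3 `CCNC(=O)Nc1ccc(S(=O)(=O)Oc2ccccc2CC)cc1`: 12000 nM

Compound 1 and compound 2 differ by 4-hydroxyphenyl in place of 2-ethylphenyl on an oxygen and in a functional assay on HT-29 cells (Homo sapiens) for cytotoxicity, read by sulforhodamine B assay, with a stated time of 48 h (on this read-out lower numbers stand for stronger inhibition and higher numbers for weaker inhibition), this gives a 2.3-fold higher number from compound 1 to compound 2 (0.36 log units; beyond the scatter). Compound 3 has the same atoms as compound 1 joined differently, but the difference between the two cores is not broken down here. Compound 3 gives the lowest number of the three in this assay, with compound 1 showing 33000 nM and compound 2 showing 75000 nM.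

Compound 4 `CCNC(=O)Nc1ccc(S(=O)(=O)Oc2ccc(O)cc2)cc1` is not yet measured and differs from compound 3 by 4-hydroxyphenyl in place of 2-ethylphenyl on an oxygen, the same change at the same place as between compound 1 and compound 2. Among the measured compounds shown here, the expected step is a 2.3-fold higher number from compound 3 to compound 4 (0.37 log units; beyond the scatter), matching the earlier step of a 2.3-fold higher number from compound 1 to compound 2 (0.36 log units; beyond the scatter), which is the only measured instance of this change. Compound 4 is estimated at 28000 nM, expected between 12000 nM and 70000 nM.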

Compound 4, half-maximal inhibitory concentration: 12000 nM
Estimate against measurement, compound 4: 2.3-fold (0.37 log units) above; the range from low to high includes it.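

On the core of compound 3, 4-hydroxyphenyl in place of 2-ethylphenyl on the oxygen gives no change at the digits printed from compound 3 to compound 4 (within the scatter) in this assay. Set beside the same change on the core of compound 1, this step cannot be told apart from the earlier one: the same change on two cores in this assay, a 2.3-fold higher number (0.36 log units; beyond the scatter) from compound 1 to compound 2 and no change at the digits printed (within the scatter) from compound 3 to compound 4, 2.3-fold (0.36 log units) apart, within the scatter of two such steps. The two cores therefore give no evidence that the change behaves differently from one to the other, but a single pair on each core does not prove that it carries over unchanged, and the step's size on either core remains loosely fixed.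

Still open, from the compounds shown here alone, is whether a phenyl group bearing an amine or a carboxylic acid in place of the hydroxyl would behave alike on both cores. Also open, going by these compounds, is how a longer chain in place of the ethyl on the urea would affect either core.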